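The source may report more compounds than this note shows. Statements on the series, on what has been measured and on what is new or still open speak of the compounds shown alone.

Measured so far:
Compound 1 `CC(C)CCn1c(CN2C(=O)C(C)(O)c3ccccc32)nc2ccccc21`: in an ADME assay on HEp-2 cells (Homo sapiens) for cytotoxicity (on this read-out lower numbers stand for higher toxicity in this test and higher numbers for lower toxicity in this test), compound 1 gives 101000 nM.
Compound 2 `N#CCCCCn1c(CN2C(=O)CS(=O)(=O)c3ccccc32)nc2ccccc21`: compound 2 reaches only the limit of the test, > 270000 nM.
Compound 3 `O=C1N(Cc2nc3ccccc3n2CCCCF)c2ccccc2S(=O)(=O)N1C1CC1`: compound 3 gives 111000 nM.

Of the two numbers available, compound 3 and compound 1 sit together within the usual scatter of this assay, so no order between them is claimed; the third value, that of compound 2, is a limit only (the limit of > 270000 nM in this assay, at which 1 of the 3 values shown sits).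

Compound 4 `CN1C(=O)N(Cc2nc3ccccc3n2CCCCF)c2ccccc2S1(=O)=O` has not yet been measured. It differs from compound 3 by methyl in place of cyclopropyl on an amide-type nitrogen in a ring. Going by the values given here, no step between two measured compounds touches this position, so there is nothing to scale from. The expectation is a step of no size beyond the scatter, a 1.0-fold higher number from compound 3 to compound 4 (0.02 log units; within the scatter). Compound 4 is therefore expected to give about 115000 nM, between 50000 nM and 270000 nM, with a fair chance that only a limit is reported.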

Compound 4, half-maximal cytotoxic concentration: 87700 nM
For compound 4 the middle estimate is 1.3-fold (0.12 log units) above the measured one; the range from low to high includes it.
By their numbers in this assay, from the lowest: compounds 4, 1 and 3 (each within the scatter of the next). At a limit, above all of these: compound 2.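

Going by these compounds alone, at the amide-type nitrogen in a ring, methyl in place of cyclopropyl gives a 1.3-fold lower number from compound 3 to compound 4 (0.10 log units; within the scatter) in this assay, the first step that can be read at this position. In this test, the two groups are not told apart here, so the three-membered ring of carbon only is not needed to stay within the scatter. Nothing on hand bears on this step. Still open, on these data alone, is whether an amine, a carboxylic acid or a longer chain on this nitrogen would also stay within the scatter.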